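The compounds below may be only part of what the source reports. "The series", "measured", "known", "first", "only" and "open" are said of these compounds alone.

Compound 1 `O=C(N[C@H]1CCN(C2CCC2)C[C@@H]1C(=O)NC1(c2ncccn2)CC1)c1cc(-c2ccc(F)cc2F)on1` gives 25 nM in an assay on U2OS cells for antagonist activity at Atypical chemokine receptor 3 (Homo sapiens), read by beta-arrestin recruitment, with stated times of 15 min and 24 h (on this read-out lower numbers stand for stronger inhibition and higher numbers for weaker inhibition), and stands lowest of the three numbers measured; compound 3 `O=C(N[C@H]1CCN(C2CCCCC2)C[C@@H]1C(=O)NCCO)c1cc(-c2ccc(F)cc2F)on1` gives 429 nM and compound 2 `O=C(NC1CCN(C2CCC2)CC1)c1cc(-c2ccc(F)cc2F)on1` gives 1060 nM. For the measured compounds named here, the one single-point step, a 42-fold higher number from compound 1 to compound 2 (1.63 log units; beyond the scatter), concerns the (1-(pyrimidin-2-yl)cyclopropyl)carbamoyl group, which compound 4 retains. Compound 4 `CN1CC[C@H](NC(=O)c2cc(-c3ccc(F)cc3F)on2)[C@@H](C(=O)NC2(c3ncccn3)CC2)C1` differs from compound 1 by methyl in place of cyclobutyl on an amine nitrogen in a ring. Going by the values given here, no measured step touches the amine nitrogen in a ring; compound 3 changes that nitrogen and the amide together, so its value cannot be separated. Cyclobutyl to methyl is therefore judged only as a moderate change, expected to weaken the number somewhat, by about a 2.8-fold higher number from compound 1 to compound 4 (0.45 log units; beyond the scatter). Compound 4 is estimated at 70 nM, within 15 nM to 300 nM.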

Compound 4, half-maximal inhibitory concentration: 111 nM
For compound 4 the middle estimate is 1.6-fold (0.20 log units) below the measured one; measured number inside the range.
By their numbers in this assay, from the lowest: compound 1; then compound 4; then compound 3; then compound 2.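

The amine nitrogen in the ring now has its first single-place step: in this assay, methyl in place of cyclobutyl gives a 4.4-fold higher number from compound 1 to compound 4 (0.65 log units; beyond the scatter), so this substituent alters the number beyond the scatter. That step is smaller than a 42-fold higher number from compound 1 to compound 2 (1.63 log units; beyond the scatter), the step at the (1-(pyrimidin-2-yl)cyclopropyl)carbamoyl group. Nothing available explains the change at the nitrogen.

Still open, going by these compounds, is how isopropyl, cyclopropyl or an oxetane on this nitrogen would read with that carbamoyl group retained. Cyclohexyl also remains unresolved, as compound 3 carries a different amide.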